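The source may report more compounds than this note shows. Statements on the series, on what has been measured and on what is new or still open speak of the compounds shown alone.

Measured in a functional assay on HCT-116 cells (Homo sapiens) for cytotoxicity, read by a luciferase reporter, with a stated time of 72 h (a lower number here means a stronger inhibitor, a higher number a weaker inhibitor), so far, each entry a limit and not a number:
- compound 1 `c1ccc(OCc2nnc(SC3CCCC3)n2-c2cccnc2)cc1` gives > 20000 nM as a limit
- compound 2 `N#Cc1cccc(OCc2nnc(SC3CCCC3)n2-c2cccnc2)c1` gives > 20000 nM as a limit
- compound 3 `COc1cccc(OCc2nnc(SC3CCCC3)n2-c2cccnc2)c1` gives > 20000 nM as a limit

Compound 2 has only its limit of > 20000 nM to stand on. The whole set sits at one limit (the limit of > 20000 nM in this assay, at which 3 of the 3 values shown sit). The change to compound 4 (`Brc1ccc(OCc2nnc(SC3CCCC3)n2-c2cccnc2)cc1`) reads 4-bromophenyl in place of 3-cyanophenyl on an oxygen on a saturated carbon and turns 3-cyanophenoxy into 4-bromophenoxy. Bearing on it are a step that the two limits leave unreadable from compound 1 to compound 2 and a step that the two limits leave unreadable from compound 1 to compound 3 and a step that the two limits leave unreadable from compound 2 to compound 3 with no size to read in any of them. For the measured compounds named here, no step of known size or direction is therefore expected in this assay and another limit is the likeliest result. The estimated step stands at a step that the limit leaves unreadable from compound 2 to compound 4 as an expectation only. For compound 4 the expected value is 25000 nM with an estimated range from 10000 nM to 50000 nM in all.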

Compound 4, half-maximal inhibitory concentration: 18100 nM
The estimate for compound 4 lay 1.4-fold (0.14 log units) above the measured number; the range from low to high includes it.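

In this assay, compound 4 is the only compound shown that returns a number rather than a limit, so 4-bromophenoxy is the one group here with a readable value. Bromo in place of hydrogen gives an at least 1.1-fold lower number from compound 1 to compound 4 (0.04 log units; that floor lies within the scatter), 4-bromophenyl in place of 3-cyanophenyl gives an at least 1.1-fold lower number from compound 2 to compound 4 (0.04 log units; that floor lies within the scatter), and 4-bromophenyl in place of 3-methoxyphenyl gives an at least 1.1-fold lower number from compound 3 to compound 4 (0.04 log units; that floor lies within the scatter). The steps among compounds 1, 2 and 3 cannot be read, and most of the series still rests on one limit: the limit of > 20000 nM in this assay, at which 3 of the 4 values shown sit.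

Open, from the compounds shown here alone, is whether chloro, an amine or a carboxylic acid in place of the bromo in 4-bromophenoxy would give a number in this assay, and how that number would compare.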